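Compound 2 to compound 4: hydrogen for fluoro

The compounds below may be only part of what the source reports. "The series", "measured", "known", "first", "only" and "open" are said of these compounds alone.

Compound 1 `CN(Cc1cccc(F)c1)C(=O)c1cnc(-c2ccc(S(C)(=O)=O)c([N+](=O)[O-])c2)s1` gives > 27000 nM
Compound 2 `CN(Cc1cccc(F)c1)C(=O)c1sc(-c2ccc(S(C)(=O)=O)c([N+](=O)[O-])c2)nc1C(F)(F)F` gives > 27000 nM
Compound 3 `CC1Cc2ccccc2N1C(=O)c1sc(-c2ccc(S(C)(=O)=O)c([N+](=O)[O-])c2)nc1C(F)(F)F` gives > 27000 nM

In a functional assay on HepG2 cells (Homo sapiens) for cytotoxicity, read by luminescence, with a stated time of 72 h (a lower number here means that less compound is needed, a higher number that more compound is needed for the effect), compound 2 gives only a limit of > 27000 nM and no number. The series stands at the limit of > 27000 nM in this assay, at which 3 of the 3 values shown sit, without exception. The change to compound 4 `CN(Cc1ccccc1)C(=O)c1sc(-c2ccc(S(C)(=O)=O)c([N+](=O)[O-])c2)nc1C(F)(F)F` is hydrogen in place of fluoro on an aromatic carbon and puts hydrogen in place of fluoro on an aromatic carbon, meta to a large group. The measurements offer a step that the two limits leave unreadable from compound 1 to compound 2 and also a step that the two limits leave unreadable from compound 2 to compound 3 and neither gives a size to carry over. For a step that the limit leaves unreadable from compound 2 to compound 4 no step beyond the scatter is expected in either direction, and another limit is the likeliest report. Compound 4 is estimated at 35000 nM with an expected range from 20000 nM to 60000 nM in this assay as well.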

Compound 4, half-maximal effective concentration: > 27000 nM
Compound 4 was reported as a limit; the forecaster's own chance of this, stated with the estimate: 90%; the middle value is on the limit's open side.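

In this assay, for the compounds shown here, compound 2, compound 3 and compound 4 stand only as limits, and no step to compound 4 can be read. The compounds shown leave open whether hydrogen in place of fluoro changes the half-maximal effective concentration at all.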